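The source may hold more compounds than are shown below. What is called first, only, known or untested is meant among the compounds shown, and "the series" means these compounds.

Measured compounds:
- compound 1, `O=C(Nc1cccnc1)c1ccccc1OCc1ccccc1F` — in an assay on lysate for inhibition of phosphatidylcholine:ceramide cholinephosphotransferase 2 (Homo sapiens), read by HPLC, with stated times of 30 min and 2 h (on this read-out higher numbers stand for weaker inhibition and lower numbers for stronger inhibition), compound 1 gives 3500 nM
- compound 2, `O=C(Nc1cccnc1)c1ccccc1OCc1ccccc1Cl` — compound 2 gives 1100 nM
- compound 3, `Cc1ccccc1COc1ccccc1C(=O)Nc1cccnc1` — compound 3 gives 1500 nM

Compound 3 holds the second highest of the three numbers in this assay. Its nearest neighbour is compound 2: the step of a 1.4-fold higher number from compound 2 to compound 3 (0.13 log units; within the scatter) stays within the scatter, so the two numbers cannot be told apart. The furthest is compound 1, from which the step of a 2.3-fold lower number from compound 1 to compound 3 (0.37 log units; beyond the scatter) is modest but beyond the scatter.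

Compound 4, `O=C(Nc1cccnc1)c1ccccc1OCc1ccccc1C(F)(F)F`, is reached from compound 3 by trifluoromethyl in place of methyl on an aromatic carbon. For the measured compounds named here, three steps bear on this position. Exchanging fluoro for chloro gave a 3.2-fold lower number from compound 1 to compound 2 (0.50 log units; beyond the scatter), exchanging fluoro for methyl gave a 2.3-fold lower number from compound 1 to compound 3 (0.37 log units; beyond the scatter), and exchanging chloro for methyl gave a 1.4-fold higher number from compound 2 to compound 3 (0.13 log units; within the scatter). Going by the values given here, all three substituents other than fluoro thus sit together within the scatter, and none of the measured steps involves trifluoromethyl, so the data give no direct precedent for it. Compound 4 is therefore expected to land near compound 3, at 1500 nM, with a range from 600 nM to 4000 nM. The expected step is no change at the digits printed from compound 3 to compound 4 (within the scatter), which would remain within the scatter.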

Compound 4, half-maximal inhibitory concentration: 2100 nM
Compound 4: middle estimate off by 1.4-fold (0.15 log units), on the low side; low and high end bracket the measured number.
By their numbers in this assay, from the lowest: compounds 2, 3, 4 and 1 (each within the scatter of the next, the first and the last beyond it).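

In this assay, trifluoromethyl on this aromatic carbon gives a 1.4-fold higher number from compound 3 to compound 4 (0.15 log units; within the scatter) and thus shows that four heavy atoms in place of one bring no change that can be told from the scatter. For the compounds shown here, the other two comparisons read the same way, with a 1.9-fold higher number from compound 2 to compound 4 (0.28 log units; within the scatter) and a 1.7-fold lower number from compound 1 to compound 4 (0.22 log units; within the scatter) both within the scatter, so compound 4 cannot be assigned to either side of the one gap that the earlier compounds resolved, a 3.2-fold lower number from compound 1 to compound 2 (0.50 log units; beyond the scatter) at this same position. The compounds shown carry no measurement that could account for these numbers or explain why only the fluoro and chloro compounds stand apart.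

As far as these compounds go, whether an amine, a hydroxyl, a methoxy or a nitrile on this aromatic carbon would stay as close to these numbers remains open, as does the outcome with a longer chain. From the compounds shown here alone, it is also open whether the exchange of methyl for trifluoromethyl would read the same on another carbon of that ring or on a core other than the core of compound 1.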